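This account rests on a few compounds, and the source may have more. Where it says the series, first, only, none or still open, it means among the compounds named here.

Measured compounds in an assay for inhibition of serine/threonine-protein kinase PAK 4 (Homo sapiens), read by FRET and Z'-LYTE, with a stated time of 60 min, tested at 50 uM, in the presence of a further agent that is not named here; on this read-out lower numbers stand for a weaker effect and higher numbers for a stronger effect at the one concentration tested:
- Compound 1 `CCOC(=O)N1CCN(C(=O)c2nc(Nc3cc(C4CC4)[nH]n3)c3cc(Cl)ccc3n2)C[C@H]1C`: compound 1 gives 93.4%
- Compound 2 `C[C@@H]1CN(C(=O)c2nc(Nc3cc(C4CC4)[nH]n3)c3cc(Cl)ccc3n2)CCN1C(=O)OC(C)(C)C`: compound 2 gives 36.4%
- Compound 3 `CC(OC(=O)C(C)C)OC(=O)N1CCN(C(=O)c2nc(Nc3cc(C4CC4)[nH]n3)c3cc(Cl)ccc3n2)C[C@H]1C`: compound 3 gives 71.7%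

Compound 3 holds the second highest of the three numbers in this assay. Its nearest neighbour is compound 1, and that gap, a number 21.7 percentage points lower from compound 1 to compound 3 (beyond the scatter), lies beyond the scatter; the furthest is compound 2, where the gap a number 35.3 percentage points higher from compound 2 to compound 3 (beyond the scatter) is large. Within the data shown here, all three differ only in the group on an oxygen next to a carbonyl group, and the one step so far that exchanges one alkyl there for another, a number 57 percentage points lower from compound 1 to compound 2 (beyond the scatter), is large.

Compound 4 `C[C@@H]1CN(C(=O)c2nc(Nc3cc(C4CC4)[nH]n3)c3cc(Cl)ccc3n2)CCN1C(=O)OCc1ccccc1` carries a change at the same place: benzyl in place of 1-((isopropylcarbonyl)oxy)ethyl on an oxygen next to a carbonyl group. Among the measured compounds shown here, no measured step introduces benzyl, so only the general sensitivity of this position is known. That sensitivity is considerable, and the two groups bracketing compound 3 sit on either side of it, which leaves the direction uncertain. For compound 4 the expected step is a number 9.7 percentage points lower from compound 3 to compound 4 (within the scatter), a modest one that stays within the scatter. Compound 4 is therefore estimated to give 62% in this assay, with a range from 30% to 88%.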

Compound 4, a percentage reported as inhibition, at one concentration (the size of the read-out at that concentration, not a potency) in the serine/threonine-protein kinase PAK 4 assay: 96%
Compound 4: the middle estimate sits 34 percentage points below what was measured; the whole stated range lies below it.
By their numbers in the serine/threonine-protein kinase PAK 4 assay, from the lowest: compound 2; then compound 3; then compounds 1 and 4 (each within the scatter of the next).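

In the serine/threonine-protein kinase PAK 4 assay, benzyl on an oxygen next to a carbonyl group costs nothing against ethyl, with a number 2.6 percentage points higher from compound 1 to compound 4 (within the scatter), while a number 24.3 percentage points higher from compound 3 to compound 4 (beyond the scatter) and a number 59.6 percentage points higher from compound 2 to compound 4 (beyond the scatter) set it clearly apart from 1-((isopropylcarbonyl)oxy)ethyl and tert-butyl. The loss seen with tert-butyl is therefore not shared by every replacement of ethyl at this place, and a group with a six-membered aromatic ring of carbon only is accepted here. In a physicochemical assay, read by HPLC, in phosphate buffer, with a stated time of 2 h, at pH 7.4 (on this read-out lower numbers stand for a less stable compound and higher numbers for a more stable compound), compound 3 shows 96.6% and compound 4 shows 97.7%, a difference of a number 1.1 percentage points higher from compound 3 to compound 4 (within the scatter), so this read-out does not separate the two groups.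

No available evidence accounts for the wide spread between benzyl and tert-butyl at this place. Still open, from the compounds shown here alone, is how a phenethyl group, or a benzyl ring carrying an amine or a carboxylic acid, would behave here, and whether compound 1 and compound 4 would remain level in a full concentration series, since the serine/threonine-protein kinase PAK 4 assay reports the effect at one concentration only.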